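Ring opening of the diamine substituent on compound 2

The compounds below may be only part of what the source reports. "The series", "measured", "known", "first", "only" and "open" are said of these compounds alone.

The series shares the core of compound 1 `N[C@H]1CC[C@H](Nc2c(C(=O)NCc3ccc(F)cc3)nc(N3CCCCS3(=O)=O)c3cccnc23)CC1`. In a functional assay on HT-29 cells (Homo sapiens) for cytotoxicity, read by MTT assay, with a stated time of 72 h (a lower number here means a stronger inhibitor, a higher number a weaker inhibitor), compound 1 gives > 10000 nM, which is a limit of the assay and not a number. Compound 2 `N[C@H]1CC[C@H](Nc2c(C(=O)NCc3ccc(F)cc3)nc(Br)c3cccnc23)CC1` gives in this assay < 1000 nM, again a limit rather than a number. Compound 3 `N[C@H]1CC[C@H](Nc2c(C(=O)NCc3ccc(F)cc3)nc(N3CCCCC3)c3cccnc23)CC1` gives in this assay "not determined" (no result reported). Going by the values given here, the only measured step, an at least 10-fold lower number from compound 1 to compound 2 (1.00 log units; beyond the scatter), concerns the bromine atom on the aromatic carbon and runs between two limits, the limit of > 10000 nM in this assay, at which 1 of the 3 values shown sits, and (the limit of < 1000 nM in this assay, at which 1 of the 3 values shown sits), so its true size is not known. Compound 2 thus stands at the stronger limit without an exact number. Compound 4 `NCCCCCCNc1c(C(=O)NCc2ccc(F)cc2)nc(Br)c2cccnc12` differs from compound 2 by 6-aminohexyl in place of 4-aminocyclohexyl on a nitrogen on an aromatic ring. Among the compounds with values here, no measured step bears on this change, so no direction beyond the scatter is expected; the expected step is an at least 1.5-fold higher number from compound 2 to compound 4 (0.17 log units; that floor lies within the scatter). Compound 4 is estimated at 1500 nM, between 300 nM and 8000 nM.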

Compound 4, half-maximal inhibitory concentration: 5000 nM
Compound 4: the middle estimate sits 3.3-fold (0.52 log units) below what was measured; the measured number falls inside the stated range.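

In this assay, the ring of 4-aminocyclohexyl on this nitrogen cannot be swapped for the open 6-aminohexyl chain without loss: an at least 5.0-fold higher number from compound 2 to compound 4 (0.69 log units; beyond the scatter). Compound 4 also gives the series an exact value, 5000 nM. The step is only a floor, because compound 2 stands at a limit: the limit of < 1000 nM in this assay, at which 1 of the 4 values shown sits.

As far as these compounds go, whether the loss follows from opening the ring or from the length of the chain remains open; a shorter chain such as 4-aminobutyl would bear on this. Also open, from the compounds shown here alone, is whether the step holds when bromine is replaced.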